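A chlorophenyl in place of a pyridyl on the ring nitrogen

This account rests on a few compounds, and the source may have more. Where it says the series, first, only, none or still open, it means among the compounds named here.

Compound 1 `Nc1scc(CN2CCN(c3ccncc3)CC2)c1C(=O)c1ccc(Cl)cc1` was tested in a functional assay on CHO cells with adenosine receptor A1 (Homo sapiens) as the target, read by cAMP accumulation and immunoassay, with a stated time of 6 min, tested at 10 uM (a higher number here means a weaker effect of the compound at the concentration tested, a lower number a stronger effect), where compound 1 gives -15%. The second measured compound, compound 2 `Nc1scc(CN2CCN(c3c(F)cccc3F)CC2)c1C(=O)c1cccc(C(F)(F)F)c1`, gives 4% in this assay. Of these two numbers, compound 1 stands lowest, and compound 2 lies higher by a gap that is beyond the scatter. Compound 3 `Nc1scc(CN2CCN(c3cccc(Cl)c3)CC2)c1C(=O)c1ccc(Cl)cc1` has not yet been measured. It differs from compound 1 at a single place: 3-chlorophenyl in place of pyridin-4-yl on an amine nitrogen in a ring. No measured pair shows a step of this kind, so the change has no direct precedent among these compounds. Both measured values are small in size, leaving little sign of a strong effect at the tested concentration. Compound 3 is therefore expected to show a step of a number 7 percentage points higher from compound 1 to compound 3 (within the scatter), not beyond the scatter. The estimate for compound 3 in this assay is -8%, within a range from -28% to 14%.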

Compound 3, a percentage reported as activity, at one concentration (the size of the read-out at that concentration, not a potency): -77%
Estimate against measurement, compound 3: 69 percentage points above; the whole stated range lies above it.
By their numbers in this assay, from the lowest: compound 3; then compound 1; then compound 2.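

In this assay, the exchange of pyridin-4-yl for 3-chlorophenyl on the amine nitrogen in the ring gives a number 62 percentage points lower from compound 1 to compound 3 (beyond the scatter), and here a lower number means a stronger effect at the concentration tested. Within the data shown here, the two earlier compounds differ in more than one place, so this is the first step to show that the group at this position can, on its own, change the read-out by a large amount, with the rest of compound 1 left as it is. No measurement shown here accounts for the size of this step.

The change removes the ring nitrogen and adds the chlorine at once, so the compounds shown leave open which of the two goes with the step. A plain phenyl at this place would separate them, and a methoxy group in place of the chlorine would test whether the chlorine itself is needed.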